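This account rests on a few compounds, and the source may have more. Where it says the series, first, only, none or still open, it means among the compounds named here.

Measured in a functional assay on the whole organism for inhibition, with Rattus norvegicus as the target, read by paw edema, at a dose of 100 mg/kg by the oral route; on this read-out higher numbers stand for more inhibition at the one dose given (going by the name of the read-out) and lower numbers for less inhibition:
compound 1 `COc1ccc(NC(=O)c2c(O)c3cccnc3n(-c3ccccc3)c2=O)cc1` gives 0.3%
compound 2 `O=C(Nc1ccc(Cl)cc1)c1c(O)c2cccnc2n(-c2ccccc2)c1=O` gives 11.6%
compound 3 `COc1ccc(NC(=O)c2c(O)c3cccnc3n(-c3ccccc3)c2=O)cn1` gives 13.1%

Compound 4 `O=C(Nc1ccc(Cl)nc1)c1c(O)c2cccnc2n(-c2ccccc2)c1=O` is not yet measured in this assay.

The change from compound 3 to compound 4 is chloro in place of methoxy on an aromatic carbon. The same kind of change has been made once already, from compound 1 to compound 2: chloro in place of methoxy on an aromatic carbon, and there it gave a number 11.3 percentage points higher from compound 1 to compound 2 (beyond the scatter). The place is not identical: in compound 1 the ring is of carbon only, in compound 3 it holds one nitrogen and the exchanged group stands next to that ring nitrogen. The two cores differ as 6-methoxypyridin-3-yl in place of 4-methoxyphenyl on an amide-type nitrogen, a change that gave a number 12.8 percentage points higher from compound 1 to compound 3 (beyond the scatter). Compound 2 and compound 3 differ by a number 1.5 percentage points higher from compound 2 to compound 3 (within the scatter).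

For compound 4 a step of a number 6.9 percentage points higher from compound 3 to compound 4 (within the scatter) is expected, resting on the one earlier case, because a number 11.3 percentage points higher from compound 1 to compound 2 (beyond the scatter) was seen, taken with some doubt since the place differs. Compound 4 is therefore estimated at 20%, between 6% and 36%.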

Compound 4, a percentage reported as inhibition, in the whole organism at one dose (the size of the read-out at that dose, not a potency): 9.2%
Beside the measured number, compound 4's estimate is 10.8 percentage points above it, within the range that was stated.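

In this assay, the exchange of methoxy for chloro does not carry over from the core of compound 1 to the core of compound 3: the same change on two cores in this assay, a number 11.3 percentage points higher (beyond the scatter) from compound 1 to compound 2 and a number 3.9 percentage points lower (within the scatter) from compound 3 to compound 4, 15.2 percentage points apart, beyond the scatter of two such steps

With the ring nitrogen present, the exchange gives a number 3.9 percentage points lower from compound 3 to compound 4 (within the scatter), and the other two comparisons give a number 2.4 percentage points lower from compound 2 to compound 4 (within the scatter) and a number 8.9 percentage points higher from compound 1 to compound 4 (within the scatter). This rests on a single pair per core at one dose, so it shows no general rule for the series and gives no reason for the gap between the two steps.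

Still open, as far as these compounds go, is how an amine or a carboxylic acid would read in place of the chloro or methoxy group. Changes elsewhere on the shared core also remain open.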